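The source may hold more compounds than are shown below. What is called first, only, known or untested is meant among the compounds shown, and "the series" means these compounds.

Working notes on the series. Compound 2 `O=c1cc(CNCc2ccc(F)cc2)oc2ccc(O)c(O)c12` is the reference point. In an ADME assay on Huh-7 cells (Homo sapiens) for cytotoxicity (a higher number here means that more compound is tolerated, a lower number that less compound is tolerated), compound 2 gives > 100000 nM, which is a limit of the assay rather than a number. Going by the values given here, compound 1 `O=c1cc(CNCc2cccc(I)c2)oc2ccc(O)c(O)c12` is its only measured neighbour. In this assay compound 1 gives > 100000 nM, again a limit of the assay. The step that the two limits leave unreadable from compound 1 to compound 2 therefore cannot be sized. Among the compounds with values here, the only evidence on the measured step is the limit of > 100000 nM in this assay, at which 2 of the 2 values shown sit. The unmeasured compound 3 `O=c1cc(CNCc2ccc(Cl)cc2)oc2ccc(O)c(O)c12` differs from compound 2 by chloro in place of fluoro on an aromatic carbon. Within the data shown here, no measured step bears directly on this exchange; the sole comparison available is the one between compound 1 and compound 2, and it is unreadable. With both measured values sitting at the limit, there is no basis for expecting compound 3 to leave it, so no step beyond the scatter is expected in this assay in either direction. The expected step is a number no higher from compound 2 to compound 3 (the limit leaves the size open), within the scatter. Compound 3 is estimated at 100000 nM, with a range from 50000 nM to 200000 nM. The most likely outcome is that this assay again reports only a limit for compound 3.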

Compound 3, half-maximal cytotoxic concentration: > 100000 nM
Compound 3: a limit, no number; the forecaster's own chance of this, stated with the estimate: 85%; the middle value sits exactly at the limit.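

In this assay compound 3 gives > 100000 nM, a limit of the assay and not a number, so the steps from compound 1 and from compound 2 to compound 3 cannot be read. The compounds shown leave open the actual half-maximal cytotoxic concentration of compound 1, compound 2 and compound 3, and so whether these halogen exchanges change it at all.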